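A few compounds are considered here, and "the series" means these few. Any claim that something is new, unique, unknown or untested is made for them only; others in the source may bear on it.

Series notes. Compound 1 `CN1CCN(c2nc3c(cc2[N+](=O)[O-])c(=O)c(C(=O)O)cn3-c2ccc(F)cc2)CC1c1ccccc1` and compound 3 `CN1CCN(c2nc3c(cc2[N+](=O)[O-])c(=O)c(C(=O)O)cn3C(C)(C)C)CC1c1ccccc1` share one core; compound 2 `CCN(CC)C(=O)C1CCCN(c2nc3c(cc2[N+](=O)[O-])c(=O)c(C(=O)O)cn3-c2ccc(F)cc2)C1` and compound 4 `CCN(CC)C(=O)C1CCCN(c2nc3c(cc2[N+](=O)[O-])c(=O)c(C(=O)O)cn3C(C)(C)C)C1` share another, and the difference between the two cores is not broken down here. In an ADME assay on Vero cells (Chlorocebus sabaeus) for cytotoxicity, read by MTT assay, with a stated time of 72 h (on this read-out higher numbers stand for weaker inhibition and lower numbers for stronger inhibition), compound 1 gives 124000 nM. Compound 2 gives only a limit of the assay, > 122000 nM (the limit of > 122000 nM in this assay, at which 1 of the 3 values shown sits). Compound 3 likewise gives only a limit, > 134000 nM (the limit of > 134000 nM in this assay, at which 1 of the 3 values shown sits). The change tert-butyl in place of 4-fluorophenyl on an aromatic nitrogen gives an at least 1.0-fold higher number from compound 1 to compound 3 (0.03 log units; that floor lies within the scatter). The same change, (tert-butyl in place of 4-fluorophenyl on an aromatic nitrogen), leads from compound 2 to compound 4, and in this assay the expected step is a step that the limit leaves unreadable from compound 2 to compound 4, resting on compound 1 and compound 3 showing an at least 1.0-fold higher number from compound 1 to compound 3 (0.03 log units; that floor lies within the scatter). Compound 4 is thus expected near 130000 nM, between 95000 nM and 200000 nM, most likely again reported only as a limit.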

Compound 4, half-maximal inhibitory concentration: > 131000 nM
Compound 4 gave a limit, no number (the forecaster's own chance of this, stated with the estimate: 80%); middle value at least 1.0-fold (0.00 log units) from the limit.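

Within the data shown here, compound 2 and compound 4 are both reported only as limits in this assay, and no step between them can be read. The compounds shown leave open whether tert-butyl in place of 4-fluorophenyl changes the read-out on either core.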